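This account rests on a few compounds, and the source may have more. Where it says the series, first, only, none or still open, it means among the compounds named here.

In a functional assay on HCT-116 cells (Homo sapiens) for antiproliferative activity, read by CCK-8 assay, with a stated time of 72 h, tested at 8 uM (a lower number here means a weaker effect, a higher number a stronger effect of the compound at the concentration tested), compound 2 `CC(C)n1cnc2c(NCc3ccc(C(=O)Nc4ccccc4N)cc3)nc(Cl)nc21` gives 76%, the highest of the three numbers shown. Compound 3 `CCCCn1cnc2c(Nc3ccccc3)nc(NCOCc3ccc(C(=O)Nc4ccccc4N)cc3)nc21` gives 74.9%, within the scatter of compound 2, while compound 1 `COC(CCn1cnc2c(NCc3ccc(C(=O)Nc4ccccc4N)cc3)nc(Cl)nc21)OC` gives 11.9%, well below compound 2. Among the measured compounds shown here, the single measured change at the aromatic nitrogen of the shared core, a number 64.1 percentage points higher from compound 1 to compound 2 (beyond the scatter), shows that the group on this nitrogen can move the read-out strongly. Compound 4 `Nc1ccccc1NC(=O)c1ccc(CNc2nc(Cl)nc3c2ncn3Cc2ccccc2)cc1` differs from compound 2 by benzyl in place of isopropyl on an aromatic nitrogen. For the measured compounds named here, no measured step covers a benzyl at this place, so the direction remains open; compound 2 and compound 3 carry small alkyl groups there and stay close to each other, and a modest change is expected, a number 11 percentage points lower from compound 2 to compound 4 (beyond the scatter). Compound 4 is therefore estimated at 65%, between 35% and 90%.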

Compound 4, a percentage reported as inhibition, at one concentration (the size of the read-out at that concentration, not a potency): 11.5%
Estimate against measurement, compound 4: 53.5 percentage points above; the measured number lies below the stated range.
By their numbers in this assay, from the lowest: compounds 4 and 1 (each within the scatter of the next); then compounds 3 and 2 (each within the scatter of the next).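

In this assay benzyl in place of isopropyl on the aromatic nitrogen gives a number 64.5 percentage points lower from compound 2 to compound 4 (beyond the scatter) and so shows that a large loss at this position is not confined to the 3,3-dimethoxypropyl group. Phenyl in place of 2,2-dimethoxyethyl on the saturated chain carbon gives a number 0.4 percentage points lower from compound 1 to compound 4 (within the scatter) and leaves these two different groups at the same level. Nothing available explains the loss with benzyl. From the compounds shown here alone, whether an ethyl, a cyclohexylmethyl or a chain ending in an amine on this nitrogen would keep the read-out of compound 2 stays open.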